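A few compounds are considered here, and "the series" means these few. Any claim that something is new, unique, unknown or untested is made for them only; others in the source may bear on it.

Compound 2 `C/C(=C\C(=O)Nc1ccccc1OCCCC(=O)O)c1ccc2c(ccn2Cc2ccccc2C)c1` carries a 2-methylbenzyl group on its aromatic nitrogen. For the measured compounds named here, in an assay on Prostate gland for inhibition of steroid 5-alpha-reductase (Rattus norvegicus) (on this read-out lower numbers stand for stronger inhibition and higher numbers for weaker inhibition), compound 2 gives 69 nM, the higher of the two numbers measured so far; compound 1 `CCCCC(CC)n1ccc2cc(/C(C)=C/C(=O)Nc3ccccc3OCCCC(=O)O)ccc21` gives 7.1 nM, and the change a 9.7-fold higher number from compound 1 to compound 2 (0.99 log units; beyond the scatter) is the only measured step in this set. Compound 3 `C/C(=C\C(=O)Nc1ccccc1OCCCC(=O)O)c1ccc2c(ccn2Cc2cccc(C)c2)c1` keeps everything else and differs by 3-methylphenyl in place of 2-methylphenyl on a saturated chain carbon bound to an aromatic nitrogen. Going by the values given here, no measured step bears directly on this change: the step from compound 1 to compound 2 exchanges a branched chain for a benzyl group, whereas between compound 2 and compound 3 the same atoms are joined differently and only the name of the methylphenyl group changes. With nothing in the data pointing in either direction, compound 3 is expected to show no change at the digits printed from compound 2 to compound 3 (within the scatter), a step that stays within the scatter of this assay. The estimate for compound 3 in this assay is therefore 69 nM, with a range from 25 nM to 200 nM to allow for an unknown effect of the altered group.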

Compound 3, half-maximal inhibitory concentration: 250 nM
Beside the measured number, compound 3's estimate is 3.6-fold (0.56 log units) below it; measured number outside the range, above it.
By their numbers in this assay, from the lowest: compound 1; then compound 2; then compound 3.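

Exchanging 2-methylphenyl for 3-methylphenyl on a saturated chain carbon bound to an aromatic nitrogen gives a change beyond the scatter (a 3.6-fold higher number from compound 2 to compound 3 (0.56 log units; beyond the scatter)), so in this assay this place responds to how the same atoms are joined, and not only to whether a branched chain or a benzyl group stands there. Compared with compound 1, the 3-methylbenzyl group opens a wider gap (a 35-fold higher number from compound 1 to compound 3 (1.55 log units; beyond the scatter)) than the 2-methylbenzyl group does (a 9.7-fold higher number from compound 1 to compound 2 (0.99 log units; beyond the scatter)), and both benzyl compounds give higher numbers than the 1-ethylpentyl compound. Nothing available explains why the two methylbenzyl groups part in this way.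

The compounds shown leave open how an unsubstituted benzyl group would read at this place, and therefore whether the methyl group of compound 2, that of compound 3, or both raise or lower the number relative to it. They also leave open whether the low number of compound 1 depends on the branching of its chain, which a straight hexyl chain on the same nitrogen would test.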